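Replacing the pyridine ring of compound 2 with phenyl

This account rests on a few compounds, and the source may have more. Where it says the series, first, only, none or still open, it means among the compounds named here.

The series shares one core, seen in compound 1 `O=C(CN1C(=O)c2ccccc2C1=O)NN1C(=O)CSC1c1ccccc1O` and compound 2 `O=C(CN1C(=O)c2ccccc2C1=O)NN1C(=O)CSC1c1cccnc1`. In a physicochemical assay for lipophilicity, in phosphate buffer, measured as octanol-water partition, with a stated time of 24 h (a higher number here means a more lipophilic compound, a lower number a more polar compound), compound 1 gives 1.46, and in this assay compound 2 gives 1.25, the lower of the two numbers shown, though the step of a number 0.21 log units lower from compound 1 to compound 2 (within the scatter) stays within the scatter, so no order between them can be claimed. Compound 3 `O=C(CN1C(=O)c2ccccc2C1=O)NN1C(=O)CSC1c1ccccc1` has not been measured. It differs from compound 2 in one place: phenyl in place of pyridin-3-yl on a saturated ring carbon. Within the data shown here, only one measured step exists, and it concerns pyridin-3-yl entering in place of 2-hydroxyphenyl; no measured pair shows phenyl entering in place of pyridin-3-yl, so the change to compound 3 is not covered by a step of its own. With only the value of compound 2 as an anchor, an upward step is estimated in this assay, of the size a number 0.95 log units higher from compound 2 to compound 3 (beyond the scatter), with wide uncertainty. For compound 3 the expected value in this assay is 2.2, within a range from 1.5 to 2.9.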

Compound 3, partition coefficient: 2.23
Compound 3: the middle estimate sits 0.03 log units below what was measured; the range from low to high includes it.
By their numbers in this assay, from the lowest: compounds 2 and 1 (each within the scatter of the next); then compound 3.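

In this assay, among these compounds, the saturated ring carbon now shows a change that clears the scatter: phenyl in place of pyridin-3-yl gives a number 0.98 log units higher from compound 2 to compound 3 (beyond the scatter) and so separates two rings with the same count of heavy atoms, whereas the one earlier step at this position did not clear it. Compound 3 also pairs with compound 1 at a single place, and hydrogen in place of hydroxy on an aromatic carbon gives a number 0.77 log units higher from compound 1 to compound 3 (beyond the scatter) in the same direction, so the two rings that carry a hetero atom or a hydroxy both read beyond the scatter from phenyl, while compound 1 and compound 2 still cannot be ordered against each other. Nothing measured here accounts for either step.

The compounds shown leave open how an amine or a carboxylic acid on the phenyl ring, or a methoxy group in place of the hydroxy of compound 1, would move the number. Also open, going by these compounds, is whether cyclohexyl in place of phenyl on the saturated ring carbon would read differently from compound 3, and whether these steps would hold with another part of the shared core changed.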